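The compounds below may be only part of what the source reports. "The series", "measured", "known", "first", "only" and "open" are said of these compounds alone.

In a functional assay on CNE-2 cells (Homo sapiens) for antiproliferative activity, read by sulforhodamine B assay, with a stated time of 48 h (on this read-out lower numbers stand for stronger inhibition and higher numbers for weaker inhibition), the measured compounds give:
compound 1 `COc1ccc(/C=C/C(=O)c2ccccc2-c2ccc(F)cc2)cc1OC`: 81 nM
compound 2 `COc1ccc(/C=C/C(=O)c2ccccc2-c2ccc(F)cc2)cc1O`: 87 nM
compound 3 `COc1ccc(/C=C/C(=O)c2ccccc2-c2ccc(F)cc2)cc1B(O)O`: 21 nM

Compound 2, at 87 nM in these notes, sits level with compound 1 and apart from compound 3. For the measured compounds named here, the steps are a 1.1-fold higher number from compound 1 to compound 2 (0.03 log units; within the scatter) and a 4.1-fold lower number from compound 2 to compound 3 (0.62 log units; beyond the scatter) on the numbers so far.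

Compound 4 `COc1ccc(/C=C/C(=O)c2ccccc2-c2cccc(F)c2)cc1O` carries 3-fluorophenyl in place of 4-fluorophenyl, on an aromatic carbon ortho to a large group (3-fluorophenyl in place of 4-fluorophenyl on an aromatic carbon). Neither of those steps, nor a 3.9-fold lower number from compound 1 to compound 3 (0.59 log units; beyond the scatter) in the same set, touches the fluorophenyl group, so they bear on this change only loosely. Going by the values given here, no measured step moves the fluorine. No step beyond the scatter is expected in this assay, and no direction can be named. Expected for now is a 1.0-fold higher number from compound 2 to compound 4 (0.01 log units; within the scatter) in this estimate. Compound 4 is estimated at 90 nM (range 35 nM to 230 nM).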

Compound 4, half-maximal inhibitory concentration: 17 nM
Compound 4: middle estimate off by 5.3-fold (0.72 log units), on the high side; measured number outside the range, below it.
By their numbers in this assay, from the lowest: compounds 4 and 3 (each within the scatter of the next); then compounds 1 and 2 (each within the scatter of the next).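

In this assay, moving the fluorine alone, with 3-fluorophenyl in place of 4-fluorophenyl, gives a 5.1-fold lower number from compound 2 to compound 4 (0.71 log units; beyond the scatter), with the heavy-atom count unchanged. For the compounds shown here, the earlier steps left the fluorophenyl group untouched, so this is the first sign that the read-out responds to a change at this position. Nothing available accounts for the shift. Going by these compounds, whether the same fluorine move would carry over to compound 3 remains open. So does the outcome of replacing the fluorophenyl group with a chlorophenyl or aminophenyl group.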